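Ester versus acid in a cytotoxicity series

The source may hold more compounds than are shown below. What is called first, only, known or untested is meant among the compounds shown, and "the series" means these compounds.

Compound 1 `CC(C)N(Cc1cccc(OCCCCCC(=O)O)c1)C(=O)c1ccc(-c2ccncc2)cc1` and compound 3 `CCOC(=O)CCCCCOc1cccc(CN(C(=O)c2ccc(-c3ccncc3)cc2)C(C)C)c1` share one core, while compound 2 `CC(C)N(Cc1cccc(OCCCCCC(=O)O)c1)C(=O)c1ccc(-c2cc3ccccc3n2S(=O)(=O)c2ccccc2)cc1` and compound 4 `CCOC(=O)CCCCCOc1cccc(CN(C(=O)c2ccc(-c3cc4ccccc4n3S(=O)(=O)c3ccccc3)cc2)C(C)C)c1` share another; the difference between the two cores is not broken down here. In an ADME assay on HepG2 cells (Homo sapiens) for cytotoxicity, read by CellTiter-Glo and resazurin assay, with a stated time of 72 h (on this read-out higher numbers stand for an effect only at larger amounts of compound and lower numbers for an effect already at smaller amounts), compound 1 reaches only the limit > 26000 nM, which is a limit of the assay and not a number. Compound 3 likewise stops at the limit > 26000 nM in this assay. Compound 2 also gives only the limit > 26000 nM in this assay. The change from compound 1 to compound 3 is ethyl in place of hydrogen on an oxygen next to a carbonyl group; its size in this assay is a step that the two limits leave unreadable from compound 1 to compound 3, which follows from the limit of > 26000 nM in this assay, at which 3 of the 3 values shown sit.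

The same change is now applied on the second core, from compound 2 to compound 4: ethyl in place of hydrogen on an oxygen next to a carbonyl group. With every measured value sitting at the limit, the step is expected to be small, a step that the limit leaves unreadable from compound 2 to compound 4, resting on compound 2 at > 26000 nM and on the unreadable step from compound 1 to compound 3. Compound 4 is therefore estimated at 40000 nM, within 15000 nM to 120000 nM, most likely reported again as a limit.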

Compound 4, half-maximal effective concentration: > 26000 nM
Compound 4 ended at the assay's limit (the forecaster's own chance of this, stated with the estimate: 85%); the middle value is on the limit's open side.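

The step between compound 2 and compound 4 cannot be read in this assay, since neither value is a number, and compound 1 and compound 3 stand no differently: the limit of > 26000 nM in this assay, at which 4 of the 4 values shown sit.

The compounds shown leave open whether exchanging carboxy for ethoxycarbonyl changes the cytotoxicity read-out on either core in this assay.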